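The compounds below may be only part of what the source reports. "The series", "measured", "known", "first", "only" and "open" are said of these compounds alone.

Of the compounds shown here, three sharing one core have been measured in an ADME assay on microsomes from liver (Homo sapiens) for metabolic stability; on this read-out lower numbers stand for slow clearance and higher numbers for fast clearance. Within the data shown here, compound 2 `Cc1cccc([C@H](C)NC(=O)Cn2nnc3ccccc3c2=O)c1` gives 11 mL/min/kg, the only actual number among them. Compound 1 `C[C@@H](NC(=O)Cn1nnc2ccccc2c1=O)c1ccc(Cl)cc1` gives < 9.9 mL/min/kg, which is a limit of the assay and not a number. Compound 3 `C[C@@H](NC(=O)Cn1nnc2ccccc2c1=O)c1ccccc1` gives < 9.9 mL/min/kg, which is also a limit. For compound 1 and compound 3 the evidence is therefore (the limit of < 9.9 mL/min/kg in this assay, at which 2 of the 3 values shown sit). Neither limit allows a firm ranking against compound 2.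

The next compound, compound 4 `C[C@H](NC(=O)Cn1nnc2ccccc2c1=O)c1ccc(Br)cc1`, has not yet been measured. The change from compound 2 is this: 4-bromophenyl in place of 3-methylphenyl on a saturated chain carbon bound to an amide-type nitrogen and a saturated chain carbon. Among the measured compounds shown here, the one measured step that bears on it is a step that the two limits leave unreadable from compound 1 to compound 3, with hydrogen in place of chloro on an aromatic carbon. For the measured compounds named here, that step has no readable size to carry over, and no measured step covers 4-bromophenyl itself. The best anchor is therefore compound 2 at 11 mL/min/kg, and no shift beyond the usual scatter is expected in this assay. The expected change is a 1.1-fold lower number from compound 2 to compound 4 (0.04 log units; within the scatter). For compound 4 the estimated clearance is 10 mL/min/kg, with an expected range from 6.5 mL/min/kg to 18 mL/min/kg. The assay may well report only a limit for this compound.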

Compound 4, clearance: < 9.9 mL/min/kg
Compound 4 was reported as a limit; the forecaster's own chance of this, stated with the estimate: 50%; middle value at least 1.0-fold (0.00 log units) from the limit.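

Placing 4-bromophenyl in place of 3-methylphenyl, on a saturated chain carbon bound to an amide-type nitrogen and a saturated chain carbon, gives in this assay an at least 1.1-fold lower number from compound 2 to compound 4 (0.04 log units; that floor lies within the scatter). Among these compounds, this is the first step with a readable size, yet it is only a floor that lies within the usual scatter, so it does not establish a real change in clearance. Compound 4 is reported only as a limit, which shows that 4-bromophenyl at this position does not lift the read-out to a measurable number, and most of the series now sits at that same limit: the limit of < 9.9 mL/min/kg in this assay, at which 3 of the 4 values shown sit.

The true values of compound 1, compound 3 and compound 4 remain hidden behind their limits, so the steps between those compounds cannot be read. Going by these compounds, it also remains open whether an aromatic ring carrying an amine or a carboxylic acid in place of the bromine, or a longer chain in place of the methyl on the ring of compound 2, would give a clearance clearly separate from these values.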